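Extending the chain at the amine-bearing carbon of compound 2

The compounds below may be only part of what the source reports. "The series", "measured", "known", "first", "only" and "open" are said of these compounds alone.

Measured so far:
compound 1, `CCCCCCCCCCCCCCC[C@@H](O)[C@@H](N)[C@@H](C)O`, 19000 nM
compound 2, `CCCCCCCCCCCCCCC[C@@H](O)[C@H](C)N`, 2600 nM
compound 3, `CCCCCCCCC[C@@H](O)[C@@H](N)[C@@H](C)O`, 17000 nM

In a functional assay on HeLa cells (Homo sapiens) for antiproliferative activity, read by sulforhodamine B assay, with a stated time of 48 h (on this read-out lower numbers stand for stronger inhibition of growth and higher numbers for weaker inhibition of growth), compound 2 gives the lowest of the three numbers; compound 3 lies a step above it and compound 1 a little further. Compound 4, `CCCCCCCCCCCCCCC[C@@H](O)[C@@H](N)[C@@H](C)CC`, has not been measured. It differs from compound 2 as follows: sec-butyl in place of methyl on a saturated chain carbon bound to an amine nitrogen and a saturated chain carbon. For the measured compounds named here, only one measured step touches this place: a 7.3-fold lower number from compound 1 to compound 2 (0.86 log units; beyond the scatter). That step swapped a 1-hydroxyethyl for a methyl, whereas here a methyl grows into a sec-butyl, so the data give no direct guide to its direction. Compound 4 is therefore expected to stay near compound 2, with a 1.5-fold higher number from compound 2 to compound 4 (0.19 log units; within the scatter) as the likely outcome, and an estimated value of 4000 nM, ranging from 1500 nM to 12000 nM.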

Compound 4, concentration for 50% growth inhibition: 20000 nM
Compound 4: the middle estimate sits 5.0-fold (0.70 log units) below what was measured; measured number outside the range, above it.
By their numbers in this assay, from the lowest: compound 2; then compounds 3, 1 and 4 (each within the scatter of the next).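

In this assay, growing the methyl into a sec-butyl on the saturated chain carbon bound to an amine nitrogen weakens growth inhibition, with a 7.7-fold higher number from compound 2 to compound 4 (0.89 log units; beyond the scatter). Putting ethyl in place of hydroxy on the side chain makes no clear difference, with a 1.1-fold higher number from compound 1 to compound 4 (0.02 log units; within the scatter), so among these compounds only the methyl of compound 2 stands apart from the two larger groups. No measurement here explains this result.

From the compounds shown here alone, it remains open whether a propyl or a hydroxymethyl at this place would keep the number of compound 2 or lose it.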